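Fluorine placement on the pendant aryl of compound 2

The source may report more compounds than this note shows. Statements on the series, on what has been measured and on what is new or still open speak of the compounds shown alone.

Going by the values given here, in an ADME assay on microsomes from liver (Homo sapiens) for metabolic stability, tested at 2.5 uM (a higher number here means faster removal of the compound, a lower number slower removal), compound 2 `Cc1ccc(S(=O)(=O)c2cnc3c(F)cccc3c2-c2ccc(F)cc2)cc1F` gives 2.75 mL/min, the highest of the three numbers measured so far. Compound 3 `O=S(=O)(c1ccc(F)c(F)c1)c1cnc2c(F)cccc2c1-c1ccc(F)cc1` gives 0.78 mL/min and compound 1 `O=S(=O)(c1ccc(F)c(Cl)c1)c1cnc2c(F)cccc2c1-c1ccc(F)cc1` gives 0.19 mL/min. Compound 4 `Cc1ccc(S(=O)(=O)c2cnc3c(F)cccc3c2-c2cccc(F)c2)cc1F` is not yet measured; it differs from compound 2 in one place: 3-fluorophenyl in place of 4-fluorophenyl on an aromatic carbon. Every measured step alters the aryl on the sulfonyl sulfur: a 14-fold higher number from compound 1 to compound 2 (1.16 log units; beyond the scatter), a 4.1-fold higher number from compound 1 to compound 3 (0.61 log units; beyond the scatter), a 3.5-fold lower number from compound 2 to compound 3 (0.55 log units; beyond the scatter). Among the compounds with values here, none of them touches the ring where compound 4 changes, so no measured step bears on this change, and no step beyond the scatter is expected in this assay. Compound 4 is therefore estimated at 2.75 mL/min, within 1.2 mL/min to 6 mL/min, which means an expected no change at the digits printed from compound 2 to compound 4 (within the scatter).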

Compound 4, intrinsic clearance in a liver preparation (reported as CLH), per the amount of preparation that the assay uses: 3.92 mL/min
The estimate for compound 4 lay 1.4-fold (0.15 log units) below the measured number; low and high end bracket the measured number.
By their numbers in this assay, from the lowest: compound 1; then compound 3; then compounds 2 and 4 (each within the scatter of the next).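

Going by these compounds alone, with 3-fluorophenyl in place of 4-fluorophenyl, this assay shows a 1.4-fold higher number from compound 2 to compound 4 (0.15 log units; within the scatter) as the first measured step on this ring, as all earlier steps altered the aryl on the sulfonyl sulfur. For this pair, moving the fluorine on this ring does not separate the two compounds in this assay. No available evidence bears on this result.

The compounds shown leave open how an amine or a carboxylic acid on this ring would read in this assay and whether this fluorine move would read the same with the 3-chloro-4-fluorophenyl of compound 1 on the sulfonyl sulfur.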